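Adding a second chloro to an acid and what it may do

This account rests on a few compounds, and the source may have more. Where it says the series, first, only, none or still open, it means among the compounds named here.

Of the compounds shown here, two have been measured in an assay for inhibition of kynurenine 3-monooxygenase (Rattus norvegicus), tested at 10 uM; on this read-out higher numbers stand for more inhibition at the one concentration tested (going by the name of the read-out) and lower numbers for less inhibition. Compound 1, with the structure `COC(=O)C(=O)/C=C(\O)c1cccc(Cl)c1Cl`, carries a methyl ester on its chain, and in this assay compound 1 gives 14%. Compound 2, with the structure `O=C(O)C(=O)/C=C(\O)c1ccccc1Cl`, carries a free acid instead, and in this assay compound 2 gives 33%. Compound 2 thus stands highest of the two numbers, and the nearest value, that of compound 1, lies lower by an amount beyond the usual scatter. No single change links these two, so their values can only be set side by side.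

Compound 3, with the structure `O=C(O)C(=O)/C=C(\O)c1cccc(Cl)c1Cl`, is the next step from compound 2. The change is chloro in place of hydrogen on an aromatic carbon. For the measured compounds named here, nothing measured so far isolates the effect of this added chloro on its own; compound 1 carries chloro in that place as well but differs from compound 3 elsewhere. The step from compound 2 to compound 3 is therefore expected to be small, estimated at a number 3 percentage points lower from compound 2 to compound 3 (within the scatter), with no clear direction beyond the scatter. Compound 3 is expected to give about 30%, within a range from 10% to 50%.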

Compound 3, a percentage reported as inhibition, at one concentration (the size of the read-out at that concentration, not a potency): 33%
Estimate against measurement, compound 3: 3 percentage points below; the range from low to high includes it.
By their numbers in this assay, from the lowest: compound 1; then compounds 2 and 3 (each within the scatter of the next).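

In this assay, chloro in place of hydrogen on this aromatic carbon, ortho to a chloro group, gives no change at the digits printed from compound 2 to compound 3 (within the scatter), so the acid shows no measurable response to this second chloro at the one concentration tested. For the compounds shown here, compound 3 also supplies the first comparison that differs in one place only: with both chloro groups present, the free acid in place of the methyl ester gives a number 19 percentage points higher from compound 1 to compound 3 (beyond the scatter), so here the change at the end of the chain, not the change on the aromatic ring, moves the number beyond the scatter. Nothing available explains either of these two results.

On these data alone, it remains open whether a larger group on the same aromatic carbon, such as bromo, methoxy or trifluoromethyl, would also leave the number within the scatter of compound 2. As far as these compounds go, it is equally open whether an amide or an ethyl ester at the end of the chain would give numbers closer to compound 1 or to compound 3.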